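Compound 2 to compound 4: cycloheptyl replaces the halogenated phenyl

The compounds below may be only part of what the source reports. "The series", "measured", "known", "first", "only" and "open" are said of these compounds alone.

In an ADME assay on MT2 cells (Homo sapiens) for cytotoxicity, read by XTT assay, with a stated time of 4 days (a higher number here means that more compound is tolerated, a lower number that less compound is tolerated), compound 1 (`Cc1nc(C(NC(=O)C(=O)Nc2ccc(Cl)c(F)c2)C2CCCCN2)sc1CO`) gives 77800 nM as a measured number. Compound 2 (`Cc1nc(C(NC(=O)C(=O)Nc2ccc(Cl)c(F)c2)C2CCCCN2)sc1CCO`) stands at > 41000 nM as a limit and not a number. Compound 3 (`Cc1nc(C(NC(=O)C(=O)Nc2ccc(F)c(F)c2)C2CCCCN2)sc1CO`) stands at > 87000 nM as a limit too. Compound 2 therefore has no exact position among these values.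

The step to compound 4 (`Cc1nc(C(NC(=O)C(=O)NC2CCCCCC2)C2CCCCN2)sc1CCO`) is this one (cycloheptyl in place of 4-chloro-3-fluorophenyl on an amide-type nitrogen): cycloheptyl in place of 4-chloro-3-fluorophenyl on an amide-type nitrogen. Within the data shown here, two measured steps bear on it only indirectly, and neither replaces the whole 4-chloro-3-fluorophenyl group. The change of hydroxymethyl to the longer chain gives a step that the limit leaves unreadable from compound 1 to compound 2 and so offers no size. Fluoro in place of chloro on an aromatic carbon gives an at least 1.1-fold higher number from compound 1 to compound 3 (0.04 log units; that floor lies within the scatter) as the only readable guide. On that guide, no step beyond the scatter is expected in this assay and no direction is favoured. The estimated change is a step that the limit leaves unreadable from compound 2 to compound 4 under this expectation. The expected value for compound 4 is 50000 nM with an estimated range from 15000 nM to 120000 nM as its bounds.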

Compound 4, half-maximal cytotoxic concentration: 60000 nM
For compound 4 the middle estimate is 1.2-fold (0.08 log units) below the measured one; the measured number falls inside the stated range.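

In this assay, among these compounds, compound 2 stands at > 41000 nM as a limit and not a number, so no step from compound 2 to compound 4 can be read. The compounds shown leave open whether cycloheptyl in place of 4-chloro-3-fluorophenyl on an amide-type nitrogen shifts the half-maximal cytotoxic concentration at all, and in which direction.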